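Adding One Methoxy Close to the Assay Limit

A few compounds are considered here, and "the series" means these few. Any claim that something is new, unique, unknown or untested is made for them only; others in the source may bear on it.

Measured in a functional assay on HeLa cells (Homo sapiens) for inhibition, read by MTT assay, with a stated time of 72 h; on this read-out higher numbers stand for weaker inhibition and lower numbers for stronger inhibition:
- compound 1 `COc1cc(OC)c(OC)cc1/C=C/C(=O)c1c(OC)cc(O)c(CC=C(C)C)c1O`: > 50000 nM (a limit)
- compound 2 `COc1cc(/C=C/C(=O)c2c(O)cc(O)cc2OC)ccc1O`: > 50000 nM (a limit)
- compound 3 `COc1ccc(/C=C/C(=O)c2c(O)cc(O)cc2OC)cc1OC`: 49500 nM
- compound 4 `COc1cc(OC)c(OC)cc1/C=C/C(=O)c1c(O)cc(O)cc1OC`: not yet measured

For the measured compounds named here, compound 3 holds the only true number here, and it stands almost at the limit of the test: the limit of > 50000 nM in this assay, at which 2 of the 3 values shown sit. Compound 4 differs from compound 3 by methoxy in place of hydrogen on an aromatic carbon. Going by the values given here, only one measured step offers any guide: a number no higher from compound 2 to compound 3 (the limit leaves the size open). On these data alone, that step puts a methyl on an oxygen, not a methoxy on a carbon, and its size stays unknown. No step beyond the scatter is therefore expected in this assay, and a bare limit is quite possible. The expected change is a 1.1-fold lower number from compound 3 to compound 4 (0.04 log units; within the scatter). For compound 4 the estimated value is 45000 nM, within an expected range of 20000 nM to 90000 nM.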

Compound 4, half-maximal inhibitory concentration: 37800 nM
Compound 4: the middle estimate sits 1.2-fold (0.08 log units) above what was measured, and the stated range covers the measured number.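

In this assay, for the compounds shown here, methoxy in place of hydrogen on this aromatic carbon, ortho to a large group, gives a 1.3-fold lower number from compound 3 to compound 4 (0.12 log units; within the scatter), the first step at this position with a readable size. Hydrogen in place of 3-methylbut-2-en-1-yl on an aromatic carbon gives an at least 1.3-fold lower number from compound 1 to compound 4 (0.12 log units; that floor lies within the scatter). On these data alone, the value of compound 1 is a limit, so this step gives only a floor, and its true size remains unknown.

As far as these compounds go, whether an amine or a carboxylic acid on the same carbon would give a step beyond the scatter remains open.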